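The compounds below may be only part of what the source reports. "The series", "measured", "known", "first", "only" and "open" are said of these compounds alone.

Compound 1 `ClCc1cccc(Cn2cnc3c(Cl)ncnc32)c1` and compound 2 `ClCc1cccc(Cn2cnc3c(Cl)nc(Cl)nc32)c1` share one core; compound 3 `ClCc1ccccc1Cn1cnc2ncnc(Cl)c21` and compound 4 `ClCc1ccccc1Cn1cnc2nc(Cl)nc(Cl)c21` share another, and the difference between the two cores is not broken down here. In a functional assay on COLO 205 cells (Homo sapiens) for cytotoxicity, read by sulforhodamine B assay, with a stated time of 48 h (on this read-out lower numbers stand for higher toxicity in this test and higher numbers for lower toxicity in this test), compound 1 gives 74100 nM. Compound 2 reaches only a limit of the assay in this assay, at > 100000 nM. Compound 3 likewise reaches only a limit in this assay, at > 100000 nM. The change from compound 1 to compound 2 is chloro in place of hydrogen on an aromatic carbon, and it produced an at least 1.3-fold higher number from compound 1 to compound 2 (0.13 log units; that floor lies within the scatter). The change from compound 3 to compound 4 is the same, (chloro in place of hydrogen on an aromatic carbon). Because the limit of > 100000 nM in this assay, at which 2 of the 3 values shown sit, already holds compound 3, and the same change did not lower the number for compound 2, the step for compound 4 is expected to be about a step that the limit leaves unreadable from compound 3 to compound 4. Compound 4 is therefore estimated at 150000 nM in this assay.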

Compound 4, concentration lethal to 50% of the cells: > 100000 nM
Compound 4: no number, only a limit; the forecaster's own chance of this, stated with the estimate: 85%; the middle value does not contradict the limit.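

Compound 3 and compound 4 both stand only at a limit of this assay, and no step can be read between them. The compounds shown leave open whether chloro in place of hydrogen changes the number on this core at all.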